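The source may hold more compounds than are shown below. What is called first, only, known or untested is meant among the compounds shown, and "the series" means these compounds.

Measured so far:
- compound 1 `CN1C/C(=C\c2ccncc2)C(=O)/C(=C/c2ccccc2F)C1`: 7000 nM
- compound 2 `O=C1/C(=C/c2cccnc2)CNC/C1=C\c1ccccc1F`: > 20000 nM

Both readings come from a functional assay on SMMC-7721 cells (Homo sapiens) for cytotoxicity, read by MTT assay, with a stated time of 24 h; on this read-out higher numbers stand for weaker inhibition and lower numbers for stronger inhibition. Compound 2 gives > 20000 nM, which is a limit of the assay and not a number.

The next step leads to compound 3 `O=C1/C(=C/c2ccncc2)CNC/C1=C\c1ccccc1F`, with pyridin-4-yl in place of pyridin-3-yl on a double-bonded chain carbon bound to a double-bonded ring carbon. Among the compounds with values here, no measured step covers this change, so the expectation rests on little. Compound 1, which bears pyridin-4-yl, gives 7000 nM, so a modest move towards stronger inhibition in this assay is expected. A result for compound 3 reported only as a limit remains quite possible. The estimated change is an at least 1.4-fold lower number from compound 2 to compound 3 (0.15 log units; that floor lies within the scatter). For compound 3 the expected value is 14000 nM, with an estimated range of 5000 nM to 40000 nM.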

Compound 3, half-maximal inhibitory concentration: 18400 nM
Compound 3: the middle estimate sits 1.3-fold (0.12 log units) below what was measured, within the range that was stated.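

In this assay, as far as these compounds go, pyridin-4-yl in place of pyridin-3-yl on a double-bonded chain carbon bound to a double-bonded ring carbon amounts to an at least 1.0-fold lower number from compound 2 to compound 3 (0.03 log units; that floor lies within the scatter), so this change shows no shift that can be told from the scatter, and its true size stays unknown. Compound 2 gives a limit and not a number: the limit of > 20000 nM in this assay, at which 1 of the 3 values shown sits.

Hydrogen in place of methyl on an amine nitrogen in a ring, the one step here with two numbers, amounts to a 2.6-fold higher number from compound 1 to compound 3 (0.42 log units; beyond the scatter), so with pyridin-4-yl held fixed, the methyl on that nitrogen goes with stronger inhibition.

The compounds shown do not tell whether the step on the amine nitrogen also holds with pyridin-3-yl. From the compounds shown here alone, how a benzyl group or a longer alkyl chain on that nitrogen would read in this assay also stays open.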